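The compounds below may be only part of what the source reports. "The series", "measured", "known", "first", "only" and "open" are said of these compounds alone.

Compound 1, `CNc1cc(Oc2ccc(NC(=O)Nc3ccc(C)c(C(F)(F)F)c3)cc2)ncn1` — > 10000 nM
Compound 2, `CC(=O)Nc1cc(Oc2ccc(NC(=O)Nc3ccc(CN4CCN(C)CC4)c(C(F)(F)F)c3)cc2)ncn1` — 50 nM

Of the compounds shown here, two sharing the same diaryl-ether urea core have been measured in a functional assay on BaF3 cells (Mus musculus) for inhibition, read by CCK-8 assay, with a stated time of 72 h; on this read-out lower numbers stand for stronger inhibition of growth and higher numbers for weaker inhibition of growth. For compound 1 the outcome is a limit of the assay rather than a number, > 10000 nM, as shown by the limit of > 10000 nM in this assay, at which 1 of the 2 values shown sits. In this assay, among the compounds with values here, compound 2 gives 50 nM; it is the only compound with a number, so it stands alone and cannot be ranked against anything measured.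

The next compound, compound 3, `CCN1CCN(Cc2ccc(NC(=O)Nc3ccc(Oc4cc(NC(C)=O)ncn4)cc3)cc2C(F)(F)F)CC1`, is not yet measured. It differs from compound 2 in one place: methyl in place of hydrogen on a saturated chain carbon bound to an amine nitrogen in a ring. The change is small and sits on the saturated chain carbon bound to the amine nitrogen of the piperazine ring, far from the urea and the ether-linked core.

Within the data shown here, no measured pair offers a step of this kind, so the expected step of a 1.1-fold higher number from compound 2 to compound 3 (0.04 log units; within the scatter) from compound 2 to compound 3 is judged to lie within the usual scatter, in neither direction. Compound 3 is therefore expected to come in at about 55 nM, with a likely range from 20 nM to 150 nM.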

Compound 3, concentration for 50% growth inhibition: 38 nM
For compound 3 the middle estimate is 1.4-fold (0.16 log units) above the measured one; the measured number falls inside the stated range.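

In this assay, the change from 4-methylpiperazin-1-yl to 4-ethylpiperazin-1-yl gives the first step shown between two compounds that differ in one place: a 1.3-fold lower number from compound 2 to compound 3 (0.12 log units; within the scatter). The extra methyl on the saturated chain carbon bound to an amine nitrogen in a ring therefore leaves the growth-inhibition read-out unchanged beyond the usual scatter, so this position accepts ethyl as well as methyl, and neither compound ranks above the other. Nothing shown gives a cause for this outcome, and the single step supports only the statement that methyl and ethyl read alike here.

On these data alone, it remains open whether the same position would also accept something larger or different in kind, such as a propyl or isopropyl group, a cyclopropyl ring, a hydroxyethyl chain or a carboxylic acid, since one step from methyl to ethyl does not show how far this tolerance extends. Compound 1 differs from the other compounds in more than one place, so it gives no step to read, and its result is a limit of the assay: the limit of > 10000 nM in this assay, at which 1 of the 3 values shown sits.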